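The compounds below may be only part of what the source reports. "The series", "measured", "known", "first", "only" and "open" are said of these compounds alone.

In a functional assay on HCT-116 cells (Homo sapiens) for inhibition, read by MTT assay, with a stated time of 72 h (a higher number here means a weaker inhibitor, a lower number a stronger inhibitor), compound 1 (`Nc1ncnc2c1c(-c1cnc3[nH]ccc3c1)nn2CC(=O)NO`) gives > 150000 nM. Going by these compounds, this is a limit of the assay and not a number, so the true position of compound 1 is unknown. Compound 4 (`Nc1ncnc2c1c(-c1cnc3[nH]ccc3c1)nn2CCC(=O)NO`) differs from compound 1 by a single change on a saturated chain carbon bound to an aromatic nitrogen, where (hydroxycarbamoyl)methyl stands in place of hydroxycarbamoyl: (hydroxycarbamoyl)methyl in place of hydroxycarbamoyl on a saturated chain carbon bound to an aromatic nitrogen.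

The closest evidence comes from a pair with a different core. Compound 2 (`Nc1nc2cc(-c3nn(CCCC(=O)NO)c4ncnc(N)c34)ccc2o1`) gives 19600 nM and compound 3 (`Nc1nc2cc(-c3nn(CCCCC(=O)NO)c4ncnc(N)c34)ccc2o1`) gives 34000 nM. These two differ by the same kind of swap, (hydroxycarbamoyl)methyl in place of hydroxycarbamoyl, but three bonds along the chain from an aromatic nitrogen. Among the measured compounds shown here, that is the only measured step that bears on the change, and it is small: a 1.7-fold higher number from compound 2 to compound 3 (0.24 log units; within the scatter). One step on another core is thin support, yet it gives no reason to expect a large shift in this assay.

The expected change is therefore modest and, if it can be seen at all, toward a lower number: an at least 1.5-fold lower number from compound 1 to compound 4 (0.17 log units; that floor lies within the scatter). The assay may well report only a limit again. For compound 4 the estimated value is 100000 nM, with an expected range from 30000 nM to 250000 nM.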

Compound 4, half-maximal inhibitory concentration: > 150000 nM
Compound 4: no number, only a limit; the forecaster's own chance of this, stated with the estimate: 45%; middle value at least 1.5-fold (0.17 log units) away from the limit.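

Compound 1 and compound 4 each give only a limit and not a number, so no step between them can be read: the limit of > 150000 nM in this assay, at which 2 of the 4 values shown sit.

The compounds shown leave open where the true values of compound 1 and compound 4 lie, and whether going from (hydroxycarbamoyl)methyl to 2-(hydroxycarbamoyl)ethyl on their shared core changes the inhibition at all.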